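The source may report more compounds than this note shows. Statements on the series, on what has been measured and on what is new or still open speak of the compounds shown alone.

Measured compounds:

Compound 1 `O=c1cc(CNCc2cccc(Br)c2)oc2ccc(O)c(O)c12` gives > 100000 nM in an ADME assay on Huh-7 cells (Homo sapiens) for cytotoxicity (on this read-out higher numbers stand for lower toxicity in this test and lower numbers for higher toxicity in this test), which is a limit of the assay and not a number.
Compound 2 `O=c1cc(CNCc2cccc(I)c2)oc2ccc(O)c(O)c12` gives > 100000 nM in this assay, again a limit.
Compound 3 `O=c1cc(CNCc2ccc(Br)cc2)oc2ccc(O)c(O)c12` gives > 100000 nM in this assay, also a limit.

The change iodo in place of bromo on an aromatic carbon gives a step that the two limits leave unreadable from compound 1 to compound 2. The step that the two limits leave unreadable from compound 1 to compound 3 belongs to 4-bromophenyl in place of 3-bromophenyl on a saturated chain carbon bound to an amine nitrogen, and a step that the two limits leave unreadable from compound 2 to compound 3 is likewise unreadable. All three steps rest on (the limit of > 100000 nM in this assay, at which 3 of the 3 values shown sit), so no size can be read for any of them.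

Compound 4 `O=c1cc(CNCc2ccc(I)cc2)oc2ccc(O)c(O)c12` is not yet measured. It differs from compound 3 by iodo in place of bromo on an aromatic carbon, the same kind of change as iodo in place of bromo on an aromatic carbon from compound 1 to compound 2; the place differs in that the halogen sits meta to a large group in compound 1 and compound 2 but para to a large group in compound 3 and compound 4. The two cores differ by 4-bromophenyl in place of 3-bromophenyl on a saturated chain carbon bound to an amine nitrogen.

Given that compound 1, compound 2 and compound 3 all sit at the limit of > 100000 nM in this assay, at which 3 of the 3 values shown sit, the step that the limit leaves unreadable from compound 3 to compound 4 is expected to be small. Compound 4 is estimated at 150000 nM in this assay, with the reported value most likely a limit once more.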

Compound 4, half-maximal cytotoxic concentration: 41700 nM
Estimate against measurement, compound 4: 3.6-fold (0.56 log units) above; the whole stated range lies above it.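

In this assay, iodo in place of bromo on an aromatic carbon, para to a large group, gives an at least 2.3-fold lower number from compound 3 to compound 4 (0.37 log units; beyond the scatter), and this size is only a bound, as compound 3 is held at a limit. The same change on the core of compound 1 cannot be read, like every other step among compound 1, compound 2 and compound 3, so carrying the change from one core to the other can be neither confirmed nor ruled out: the limit of > 100000 nM in this assay, at which 3 of the 4 values shown sit. The other two readable steps, an at least 2.3-fold lower number from compound 2 to compound 4 (0.37 log units; beyond the scatter) and an at least 2.3-fold lower number from compound 1 to compound 4 (0.37 log units; beyond the scatter), also end at compound 4, so the lower number is seen on one core only and gives no size to expect on another.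

Whether the drop needs iodo and this place together rests on compound 4 alone. Going by these compounds, what a chloro, a nitrile or a carboxylic acid in that same place would give remains open, as does the true value of compound 3.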